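A few compounds are considered here, and "the series" means these few. Any claim that something is new, unique, unknown or untested is made for them only; others in the source may bear on it.

Of the compounds shown here, two of a shared core have been measured in a functional assay on the whole organism with Rattus norvegicus as the target, read by paw edema, with a stated time of 3 h, at a dose of 100 mg/kg by the oral route; a higher number here means more inhibition at the dose given (going by the name of the read-out), a lower number less inhibition. Compound 1 `Cc1ccc(-c2nc3ccccc3[nH]2)nc1` gives 19% in this assay, and compound 2 `CCCCc1ccc(-c2nc3ccccc3[nH]2)nc1` gives -16%. Within the data shown here, the one step between them, a number 35 percentage points lower from compound 1 to compound 2 (beyond the scatter), came with propyl in place of hydrogen on a saturated chain carbon bound to an aromatic carbon. Among the measured compounds shown here, compound 2 thus stands lowest of the two numbers, with compound 1 as its only neighbour, a number beyond the scatter higher.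

Compound 3 `OCc1ccc(-c2nc3ccccc3[nH]2)nc1` is not yet measured; it differs from compound 2 by hydroxy in place of propyl on a saturated chain carbon bound to an aromatic carbon. For the measured compounds named here, the only step that bears on this change is a number 35 percentage points lower from compound 1 to compound 2 (beyond the scatter), a large drop when the propyl entered. Since the propyl leaves compound 3 at that same place, the step of a number 31 percentage points higher from compound 2 to compound 3 (beyond the scatter) is expected to run upward, beyond the scatter. Compound 3 is accordingly expected to reach about 15% in this assay, within -10% to 40%.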

Compound 3, a percentage reported as inhibition, in the whole organism at one dose (the size of the read-out at that dose, not a potency): -10%
Estimate against measurement, compound 3: 25 percentage points above; the range from low to high includes it.
By their numbers in this assay, from the lowest: compounds 2 and 3 (each within the scatter of the next); then compound 1.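

In this assay, hydroxy in place of propyl gave a number 6 percentage points higher from compound 2 to compound 3 (within the scatter) and so did not separate the two groups at this saturated chain carbon bound to an aromatic carbon. Hydroxy in place of hydrogen at the same carbon gave a number 29 percentage points lower from compound 1 to compound 3 (beyond the scatter) and thus showed that the drop from compound 1 is not confined to propyl, since a carbon chain and a hydroxy group both end beyond the scatter under compound 1. No measurement at hand explains why either group goes with the lower number.

The compounds shown leave open how an amine or a carboxylic acid would read at this carbon, and whether a longer chain would stay level with compound 2. They also leave open whether any group at this place could rise above compound 1.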